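A few compounds are considered here, and "the series" means these few. Any claim that something is new, unique, unknown or untested is made for them only; others in the source may bear on it.

Measured so far in an assay on CHO cells for displacement of a labelled ligand from prostaglandin D2 receptor 2 (Homo sapiens), read by scintillation counting; on this read-out lower numbers stand for stronger inhibition and higher numbers for weaker inhibition:
- compound 1 `CCCS(=O)(=O)c1cccc(C#Cc2cc(Cl)ccc2OCC(=O)O)c1`: 9 nM
- compound 2 `CCCS(=O)(=O)c1ccc(F)c(C#Cc2cc(Cl)ccc2OCC(=O)O)c1`: 3.4 nM
- compound 3 `O=C(O)COc1ccc(Cl)cc1C#Cc1cc(CO)ccc1F`: 73 nM

Compound 3 gives the highest number of the three, well beyond the scatter from both others. Compound 4 `CS(=O)(=O)c1ccc(F)c(C#Cc2cc(Cl)ccc2OCC(=O)O)c1` is next: methylsulfonyl in place of hydroxymethyl on an aromatic carbon. The step that bears on it is the one running the other way, a 21-fold higher number from compound 2 to compound 3 (1.33 log units; beyond the scatter), where the sulfonyl was lost; a smaller sulfonyl now returns. The fluoro step a 2.6-fold lower number from compound 1 to compound 2 (0.42 log units; beyond the scatter) does not enter, since both compound 3 and compound 4 carry it. A large step down is therefore expected, probably short of the full return to compound 2. Compound 4 is estimated at 6 nM, range 2 nM to 20 nM, i.e. an expected 12-fold lower number from compound 3 to compound 4 (1.09 log units; beyond the scatter).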

Compound 4, inhibition constant: 3.3 nM
For compound 4 the middle estimate is 1.8-fold (0.26 log units) above the measured one; the measured number falls inside the stated range.
By their numbers in this assay, from the lowest: compounds 4 and 2 (each within the scatter of the next); then compound 1; then compound 3.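

In this assay, methylsulfonyl in place of hydroxymethyl on this carbon, para to a fluoro group, gives a 22-fold lower number from compound 3 to compound 4 (1.34 log units; beyond the scatter). The length of the sulfonyl chain does not separate methylsulfonyl from propylsulfonyl here, with a 1.0-fold lower number from compound 2 to compound 4 (0.01 log units; within the scatter). Nothing measured accounts for either step.

Open, as far as these compounds go, is whether a sulfonamide or a carboxylic acid on this carbon would match the sulfonyl groups, and whether a chain longer than propyl would stay level. From the compounds shown here alone, the fluoro step has been read only with propylsulfonyl, so its size with methylsulfonyl remains open.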